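Phenyl in place of 3,4-dichlorophenyl: working notes

This account rests on a few compounds, and the source may have more. Where it says the series, first, only, none or still open, it means among the compounds named here.

Measured compounds:
compound 1 `CS(=O)(=O)c1ccc(-c2oc3ccccc3c(=S)c2-c2ccc(F)cc2)cc1` — < 5%
compound 2 `CS(=O)(=O)c1ccc(-c2oc3ccccc3c(=O)c2-c2cccc(Cl)c2)cc1` — < 5%
compound 3 `CS(=O)(=O)c1ccc(-c2oc3ccccc3c(=S)c2-c2ccc(Cl)c(Cl)c2)cc1` — < 5%

In an assay on isolated protein for inhibition of prostaglandin G/H synthase 1 (Mus musculus), tested at 10 ug/mL (a lower number here means less inhibition, a higher number more inhibition at the concentration tested (going by the name of the read-out)), compound 1 gives < 5%, which is a limit of the assay and not a number. Compound 2 likewise gives < 5%, a limit. Compound 3 gives < 5%, again a limit. Within the data shown here, compound 3 therefore stands at the floor of the read-out, where every value so far sits (the limit of < 5% in this assay, at which 3 of the 3 values shown sit). Among the measured compounds shown here, the only one-place step, a step that the two limits leave unreadable from compound 1 to compound 3, is consequently unreadable, since both ends are limits.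

Compound 4 `CS(=O)(=O)c1ccc(-c2oc3ccccc3c(=S)c2-c2ccccc2)cc1` differs from compound 3 in one place: phenyl in place of 3,4-dichlorophenyl on an aromatic carbon. For the measured compounds named here, no measured step bears readably on this change. With all three values at the limit (the limit of < 5% in this assay, at which 3 of the 3 values shown sit), compound 4 is expected to stay there: the step that the limit leaves unreadable from compound 3 to compound 4 is estimated as none beyond the scatter, and compound 4 is expected at 3%, range 0% to 12%.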

Compound 4, a percentage reported as inhibition, at one concentration (the size of the read-out at that concentration, not a potency): < 5%
Compound 4: only a limit was reported; the forecaster's own chance of this, stated with the estimate: 80%; the middle value is on the limit's open side.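

No step can be read from compound 1 or compound 3 to compound 4, since both ends of each are limits: the limit of < 5% in this assay, at which 4 of the 4 values shown sit.

The compounds shown leave open whether any of these ring substitutions changes inhibition at all, as none stands clear of the limit.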